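The compounds below may be only part of what the source reports. "The series", "measured", "known", "first", "only" and "open" are said of these compounds alone.

Working notes on the series, all in an in vitro functional assay on RBL cells for antagonist activity at C-C chemokine receptor type 8 (Homo sapiens), read by FLIPR and calcium flux; on this read-out lower numbers stand for stronger inhibition and higher numbers for weaker inhibition. Compound 1 `COc1ccc2nccc(C3CN(C4CCN(Cc5cc6ccccc6[nH]5)CC4)C(=O)O3)c2c1` gives 25.1 nM. Compound 2 `COc1ccc2nccc(C3CN(C4CCN(Cc5ccc6ccccc6c5)CC4)C(=O)O3)c2c1` gives 1260 nM, so that a 50-fold higher number from compound 1 to compound 2 (1.70 log units; beyond the scatter). Compound 3 `COc1ccc2nccc(C3CN(C4CCN(C)CC4)C(=O)O3)c2c1` returns only a limit, < 50200 nM, which is the limit of < 50200 nM in this assay, at which 1 of the 3 values shown sits. Because of that limit the steps a step that the limit leaves unreadable from compound 1 to compound 3 and a step that the limit leaves unreadable from compound 2 to compound 3 have no readable size. Compound 4 `COc1ccc2nccc(C3CN(C4CCN(Cc5cccc(Cl)c5)CC4)C(=O)O3)c2c1` is not yet measured; it differs from compound 3 by 3-chlorophenyl in place of hydrogen on a saturated chain carbon bound to an amine nitrogen in a ring. The measured steps that bear on it are those from compound 3 to compound 1 and to compound 2, both unreadable in size, while the two measured aromatic groups span a 50-fold higher number from compound 1 to compound 2 (1.70 log units; beyond the scatter). A step of the size a step that the limit leaves unreadable from compound 3 to compound 4 towards a stronger number is expected on this assay. Compound 4 is therefore estimated at 1000 nM, between 150 nM and 8000 nM.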

Compound 4, half-maximal inhibitory concentration: 6310 nM
Compound 4: the middle estimate sits 6.3-fold (0.80 log units) below what was measured; the measured number falls inside the stated range.
By their numbers in this assay, from the lowest: compound 1; then compound 2; then compound 4.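

In this assay, a single aromatic ring on this saturated chain carbon gives a weaker number than either fused group, with a 5.0-fold higher number from compound 2 to compound 4 (0.70 log units; beyond the scatter) and a 250-fold higher number from compound 1 to compound 4 (2.40 log units; beyond the scatter). The order among these three aromatic groups is thus 1H-indol-2-yl, naphthalen-2-yl, then 3-chlorophenyl, each gap beyond the scatter. Compound 3 returns a limit, so no step to or from it can be read, including the gain from methyl to 3-chlorobenzyl: the limit of < 50200 nM in this assay, at which 1 of the 4 values shown sits.

Open, as far as these compounds go, is how 3-pyridyl or an aminophenyl group would read here. Also open, from the compounds shown here alone, is whether a longer chain carrying the 1H-indol-2-yl group keeps the number of compound 1.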